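The source may report more compounds than this note shows. Statements on the series, on what has been measured and on what is new or still open speak of the compounds shown alone.

Of the compounds shown here, three have been tested in an assay on NIH3T3 cells for binding affinity to melatonin receptor type 1A (Homo sapiens); a higher number here means a weaker inhibitor, a lower number a stronger inhibitor. Compound 1 `CC(=O)NCCCc1cccc2oc(CCCCc3ccccc3)cc12` gives 19 nM. Compound 2 `CC(=O)N[C@H]1CCN(c2cccc3oc(CCCCc4ccccc4)cc23)C1` gives 22 nM, and the step of a 1.2-fold higher number from compound 1 to compound 2 (0.06 log units; within the scatter) shows that this exchange of the side chain makes no real difference. Compound 3 `CC(C)C(=O)N[C@H]1CCN(c2cccc3oc(CCCCc4ccccc4)cc23)C1` gives 105 nM, and the step of a 4.8-fold higher number from compound 2 to compound 3 (0.68 log units; beyond the scatter) is a modest loss. For the measured compounds named here, on the numbers so far compound 3 thus stands highest, weaker than both of its companions.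

Compound 4 `CCNC(=O)N[C@H]1CCN(c2cccc3oc(CCCCc4ccccc4)cc23)C1` alters the same carbonyl carbon once more: ethylamino in place of isopropyl on a carbonyl carbon. Going by the values given here, the group that leaves and the group that enters are of the same heavy-atom count, but the newcomer brings a hydrogen-bond donor, something that none of the measured compounds carries at this position. Among the compounds with values here, the only step that bears on the substituent of the carbonyl carbon is a 4.8-fold higher number from compound 2 to compound 3 (0.68 log units; beyond the scatter), which tells how much the change from methyl to isopropyl cost, yet nothing measured here tells what the new nitrogen does. The expectation for compound 4 therefore stays near compound 3, with wide room on both sides, and the estimated step is a 1.8-fold lower number from compound 3 to compound 4 (0.24 log units; within the scatter). Compound 4 is expected to give about 60 nM, within 15 nM to 250 nM.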

Compound 4, inhibition constant: 39 nM
Compound 4: the middle estimate sits 1.5-fold (0.19 log units) above what was measured, within the range that was stated.
By their numbers in this assay, from the lowest: compounds 1, 2 and 4 (each within the scatter of the next, the first and the last beyond it); then compound 3.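

Exchanging isopropyl for ethylamino on this carbonyl carbon gives a 2.7-fold lower number from compound 3 to compound 4 (0.43 log units; beyond the scatter) in this assay, so two groups with the same heavy-atom count are not interchangeable here, and the count alone does not set the value. The step of a 1.8-fold higher number from compound 2 to compound 4 (0.25 log units; within the scatter) adds that a group of this count need not cost what isopropyl cost: compound 4 cannot be told apart from compound 2 even though ethylamino is the larger group than methyl. Nothing available on these compounds gives a reason for the difference between isopropyl and ethylamino.

Whether the nitrogen itself accounts for that difference remains open, and an ethoxy group on the same carbonyl carbon, with an oxygen in place of that nitrogen, would bear on the question. Also open, on these data alone, is how far the group can grow at this position, which a longer chain such as butylamino or a ring-bearing group such as phenylamino would begin to show.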